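Chloro for Methyl on the Shared Core

A few compounds are considered here, and "the series" means these few. Any claim that something is new, unique, unknown or untested is made for them only; others in the source may bear on it.

Three compounds have been measured in a functional assay on CHO cells for antagonist activity at transient receptor potential cation channel subfamily V member 1 (Rattus norvegicus), read by calcium flux, at pH 5; on this read-out higher numbers stand for weaker inhibition and lower numbers for stronger inhibition:

Compound 1, `Fc1cc(-c2nc(N3CCN(c4ncccc4C(F)(F)F)CC3)[nH]c2-c2ccc(C(F)(F)F)cc2)cc(F)c1F`, gives 20 nM.
Compound 2, `Fc1cc(F)cc(-c2nc(N3CCN(c4ncccc4C(F)(F)F)CC3)[nH]c2-c2ccc(C(F)(F)F)cc2)c1`, gives 85 nM.
Compound 3, `Cc1nc(N2CCN(c3ncccc3C(F)(F)F)CC2)[nH]c1-c1ccc(C(F)(F)F)cc1`, reaches only a limit of the assay, > 4000 nM.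

Compound 3 therefore stands at the limit of > 4000 nM in this assay, at which 1 of the 3 values shown sits, and nothing more precise is known about it. Compound 4, `FC(F)(F)c1ccc(-c2[nH]c(N3CCN(c4ncccc4C(F)(F)F)CC3)nc2Cl)cc1`, differs from compound 3 in one place: chloro in place of methyl on an aromatic carbon. For the measured compounds named here, none of the measured steps exchanges methyl for chloro. The known steps concern other places: a 4.3-fold higher number from compound 1 to compound 2 (0.63 log units; beyond the scatter), and the two large losses an at least 200-fold higher number from compound 1 to compound 3 (2.30 log units; beyond the scatter) and an at least 47-fold higher number from compound 2 to compound 3 (1.67 log units; beyond the scatter), where a substituted phenyl group gives way to methyl. Compound 4 also lacks that phenyl group and otherwise keeps everything of compound 3. Going by the values given here, with no measured step bearing directly on the exchange, the expectation for compound 4 in this assay is no step beyond the scatter, a step that the limit leaves unreadable from compound 3 to compound 4. The estimate for compound 4 is 5000 nM, ranging from 1000 nM to 25000 nM, with a real chance that only a limit is reported again.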

Compound 4, half-maximal inhibitory concentration: > 4000 nM
Compound 4 ended at the assay's limit (the forecaster's own chance of this, stated with the estimate: 60%); the middle value is on the limit's open side.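

Putting chloro in place of the methyl of compound 3 does not bring inhibition back into the measurable range in this assay: compound 4 also reaches only a limit, so the step between these two compounds cannot be read. Chloro in place of the aryl groups costs as much as methyl did as far as can be seen, with an at least 47-fold higher number from compound 2 to compound 4 (1.67 log units; beyond the scatter) and an at least 200-fold higher number from compound 1 to compound 4 (2.30 log units; beyond the scatter). Of the compounds shown, only those carrying a fluorinated phenyl group at this position give a measurable value, while methyl and chloro both end at the same point: the limit of > 4000 nM in this assay, at which 2 of the 4 values shown sit.

As far as these compounds go, how far beyond the limit compound 3 and compound 4 lie remains unknown. From the compounds shown here alone, it also remains open whether a plain phenyl ring or a longer chain such as butyl would restore inhibition at this position.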